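Swapping fluorine for chlorine on the shared core

A few compounds are considered here, and "the series" means these few. Any claim that something is new, unique, unknown or untested is made for them only; others in the source may bear on it.

Of the compounds shown here, three of one shared core have been measured in a functional assay on the whole organism (strain Albino) with Mus musculus as the target, with a stated time of 0.5 h; a higher number here means that more compound is needed for the effect, a lower number that less compound is needed. Compound 1 `COc1ccc(-c2cc(-c3ccc(F)cc3)nc(NC(=O)N/N=C\c3ccc([N+](=O)[O-])cc3)n2)cc1OC` gives 100 mg/kg. Compound 2 `C/C(=N/NC(=O)Nc1nc(-c2ccc(C)cc2)cc(-c2ccc(F)cc2)n1)c1ccc([N+](=O)[O-])cc1` gives 100 mg/kg. Compound 3 `C/C(=N/NC(=O)Nc1nc(-c2ccc(C)cc2)cc(-c2ccc(F)cc2)n1)c1ccc(Cl)cc1` gives 30 mg/kg, the lowest of the three numbers, and its distance to each of the other two is beyond the scatter. Among the compounds with values here, the one step among measured compounds that differs in a single place is a 3.3-fold lower number from compound 2 to compound 3 (0.52 log units; beyond the scatter), a change on the ring attached through the hydrazone part of the molecule.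

Compound 4 `C/C(=N/NC(=O)Nc1nc(-c2ccc(C)cc2)cc(-c2ccc(Cl)cc2)n1)c1ccc(Cl)cc1` differs from compound 3 in another place: chloro in place of fluoro on an aromatic carbon. Within the data shown here, no measured pair shows this particular exchange, so the step from compound 2 to compound 3 speaks to a different group and a different ring and does not bear directly on it. With nothing to point in either direction, the expectation for compound 4 in this assay is a step of no change at the digits printed from compound 3 to compound 4 (within the scatter), that is, no change beyond the scatter. The estimate for compound 4 is therefore 30 mg/kg, with a range from 10 mg/kg to 100 mg/kg.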

Compound 4, dose for half-maximal effect: 30 mg/kg
Compound 4: middle estimate and measured number agree at the digits printed; measured number inside the range.
By their numbers in this assay, from the lowest: compounds 3 and 4 (each within the scatter of the next); then compounds 1 and 2 (each within the scatter of the next).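

In this assay, within the data shown here, putting 4-chlorophenyl in place of 4-fluorophenyl gives no change at the digits printed from compound 3 to compound 4 (within the scatter), and this is the first reading at this position, since the only earlier step concerned the ring at the other end of the molecule. For this one pair, the position accepts chloro as readily as fluoro, so these two halogens on an aromatic carbon, para to a large group, cannot be told apart in this test. No measurement offers an explanation for why the two compounds read alike.

As far as these compounds go, both halogens are single atoms, so it remains open whether a larger or quite different group at this position, such as an amine or a carboxylic acid, would also leave the number unmoved. From the compounds shown here alone, it is also open whether the same exchange would read the same with nitro in place of chloro on the other ring.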